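Sulfanyl in Place of Methylamino on the Aromatic Carbon

The source may hold more compounds than are shown below. What is called first, only, known or untested is meant among the compounds shown, and "the series" means these compounds.

Measured compounds:
compound 1, `Cn1c(=O)cnn(CCCCN2CCN(c3ccccc3OCCCF)CC2)c1=O`, in an assay for displacement of a labelled ligand from Adrenergic receptor alpha-1 (Homo sapiens) (on this read-out higher numbers stand for weaker inhibition and lower numbers for stronger inhibition), compound 1 gives 280 nM
compound 2, `CNc1ccccc1N1CCN(CCCCn2ncc(=O)n(C)c2=O)CC1`, compound 2 gives 450 nM
compound 3, `Cn1c(=O)cnn(CCCCN2CCN(c3ccc(F)cn3)CC2)c1=O`, for compound 3 the assay reports only a limit, > 10000 nM

Compound 2 holds the highest of the two numbers; the nearest is compound 1, and the step of a 1.6-fold higher number from compound 1 to compound 2 (0.21 log units; within the scatter) lies within the scatter. Compound 3 sits at the limit of > 10000 nM in this assay, at which 1 of the 3 values shown sits, a limit rather than a number. The step of an at least 22-fold higher number from compound 2 to compound 3 (1.34 log units; beyond the scatter) is large, but that change sits on an amine nitrogen in a ring and so bears little on what follows.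

Compound 4, `Cn1c(=O)cnn(CCCCN2CCN(c3ccccc3S)CC2)c1=O`, differs from compound 2 by sulfanyl in place of methylamino on an aromatic carbon. The measured step that bears on it is the earlier change on the same aromatic carbon, from compound 1 to compound 2, which stayed within the scatter. Compound 4 is therefore expected to move little in this assay, an expected step of a 1.3-fold higher number from compound 2 to compound 4 (0.12 log units; within the scatter). The estimate for compound 4 is 600 nM, within a range from 250 nM to 1500 nM.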

Compound 4, inhibition constant: > 10000 nM
Compound 4: no number, only a limit; the forecaster's own chance of this, stated with the estimate: 5%; at least 16-fold (1.22 log units) between middle value and limit.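

In this assay, this aromatic carbon proved far less tolerant than the step between compound 1 and compound 2 had suggested: sulfanyl in place of methylamino gave an at least 22-fold higher number from compound 2 to compound 4 (1.34 log units; beyond the scatter), and sulfanyl in place of 3-fluoropropoxy gave an at least 35-fold higher number from compound 1 to compound 4 (1.55 log units; beyond the scatter). Compound 4 gives a limit and not a number: the limit of > 10000 nM in this assay, at which 2 of the 4 values shown sit. The step between compound 3 and compound 4 cannot be read.

As far as these compounds go, whether a methylsulfanyl or a hydroxyl group on this aromatic carbon would return a measurable number, as methylamino and 3-fluoropropoxy do, or would also reach the limit remains open. Also open, from the compounds shown here alone, is how far the true value of compound 4 lies beyond its limit, and whether the 2-sulfanylphenyl group would give the same result with a shorter chain.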